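Working notes: furan-3-yl to thiophen-3-yl exchange

This account rests on a few compounds, and the source may have more. Where it says the series, first, only, none or still open, it means among the compounds named here.

Measured in a functional assay on A-375 cells (Homo sapiens) for antiproliferative activity; a lower number here means a stronger inhibitor, a higher number a weaker inhibitor:
- compound 1 `O=C(Nc1ccc(-c2cccnc2)cc1)C1CCCN(Cc2ccc(F)c(F)c2)C1`: 610 nM
- compound 2 `O=C(Nc1ccc(-c2ccoc2)cc1)C1CCCN(Cc2ccc(F)c(F)c2)C1`: 1290 nM

Within the data shown here, of these two numbers, the higher belongs to compound 2 at 1290 nM, and the only comparison available is compound 1 at 610 nM. The next compound to be measured is compound 3 `O=C(Nc1ccc(-c2ccsc2)cc1)C1CCCN(Cc2ccc(F)c(F)c2)C1`, which carries thiophen-3-yl in place of furan-3-yl on an aromatic carbon of a six-membered aromatic ring of carbon only, para to a large group: thiophen-3-yl in place of furan-3-yl on an aromatic carbon. Among the measured compounds shown here, one measured step bears on this exchange, a change of group at the same place: a 2.1-fold higher number from compound 1 to compound 2 (0.33 log units; beyond the scatter). That step is modest and only just clears the scatter. For the measured compounds named here, no measured compound carries thiophen-3-yl, so the data fix no direction. In this assay a step no larger than that modest one is therefore expected, most likely within the scatter. The estimated outcome is a 1.3-fold lower number from compound 2 to compound 3 (0.11 log units; within the scatter). For compound 3 the expected value is 1000 nM, with an estimated range of 500 nM to 2000 nM.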

Compound 3, half-maximal inhibitory concentration: 950 nM
Compound 3: middle estimate off by 1.1-fold (0.02 log units), on the high side; measured number inside the range.
By their numbers in this assay, from the lowest: compounds 1, 3 and 2 (each within the scatter of the next, the first and the last beyond it).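

In this assay, the step from furan-3-yl to thiophen-3-yl is a 1.4-fold lower number from compound 2 to compound 3 (0.13 log units; within the scatter), and the step from pyridin-3-yl to thiophen-3-yl is a 1.6-fold higher number from compound 1 to compound 3 (0.19 log units; within the scatter), so compound 3 cannot be told apart from either neighbour. Among these compounds, at this place, on an aromatic carbon para to a large group, thiophen-3-yl therefore sits within the scatter of both compound 1 and compound 2, even though a 2.1-fold higher number from compound 1 to compound 2 (0.33 log units; beyond the scatter) remains the one step in the set beyond the scatter; sulfur for oxygen in the five-membered aromatic ring, at an unchanged heavy-atom count, gives no difference that can be read. No measurement on hand bears on why these three groups give such close numbers.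

From the compounds shown here alone, the three groups at this place are all aromatic rings with one hetero atom, so it remains open whether a non-aromatic group on the same carbon, such as an amine, a carboxylic acid or a longer chain, would give a step well beyond the scatter. All three compounds also share the rest of the structure, which leaves open how far changes elsewhere in the shared core would move the number.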